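Hydroxyalkyl amide in place of cyclobutyl amide

The compounds below may be only part of what the source reports. "The series", "measured", "known", "first", "only" and "open" are said of these compounds alone.

In an ADME assay on microsomes (Homo sapiens) for metabolic stability (a lower number here means that the compound disappears faster, a higher number that the compound lasts longer), compound 2 `O=C(C1CCC1)N1N=CCC1c1ccccc1` gives 1.38 h, the lowest of the two numbers recorded in this series. Compound 1 `N#Cc1cc(N2CCC(C(=O)N3N=CC[C@H]3c3cc(F)cc(F)c3)CC2)ncn1` gives 3.3 h in this assay, a difference from compound 2 that sits beyond the usual scatter of repeated measurements. Compound 3 `O=C(c1cc[nH]n1)N1CCC(C(=O)N2N=CCC2c2ccccc2)CC1` returns only a limit in this assay, > 2.75 h, not a number. The one limit recorded, (the limit of > 2.75 h in this assay, at which 1 of the 3 values shown sits), therefore stands apart from the two numbered values and is not used for comparison.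

The next compound, compound 4 `CC(C)(CO)C(=O)N1N=CCC1c1ccccc1`, follows from compound 2 by a single change: 1-(hydroxymethyl)-1-methylethyl in place of cyclobutyl on a carbonyl carbon. No pair of measured compounds in the series differs by this kind of exchange, so there is no measured step to lean on, and no reason for a direction can be drawn from the data at hand. The expectation for compound 4 in this assay is therefore kept close to compound 2, with the step from compound 2 to compound 4 expected at a 1.2-fold higher number from compound 2 to compound 4 (0.06 log units; within the scatter), a change that would not clearly exceed the scatter. Compound 4 is estimated to give 1.6 h in this assay, with a range from 0.8 h to 3.2 h.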

Compound 4, half-life: > 1.5 h
Compound 4 gave a limit, no number; the forecaster's own chance of this, stated with the estimate: 10%; the middle value does not contradict the limit.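

In this assay compound 4 returns a limit and not a number: the limit of > 1.5 h in this assay, at which 1 of the 4 values shown sits.

At the carbonyl carbon whose other neighbours are amide-type nitrogen in a ring, the exchange of cyclobutyl for 1-(hydroxymethyl)-1-methylethyl gives an at least 1.0-fold higher number from compound 2 to compound 4 (0.03 log units; that floor lies within the scatter), so the floor of this step does not separate the two compounds. Among the compounds shown here, this is the first step that can be read at this position, and it shows that the four-membered carbon ring can give way to an open group carrying oxygen with no sign of a shorter half-life, although the size of any gain remains unknown.

The compounds shown leave open how far the true half-life of compound 4 lies beyond its limit, and so whether the exchange changes the half-life by more than the usual scatter. They also leave open how an amine, a carboxylic acid or a longer chain with a terminal hydroxyl group on the same carbonyl carbon would compare with cyclobutyl and with 1-(hydroxymethyl)-1-methylethyl.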